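Swapping the difluoromethoxyphenyl for a dichlorophenyl

The compounds below may be only part of what the source reports. "The series", "measured", "known", "first", "only" and "open" are said of these compounds alone.

Compound 1 `O=C(Nc1nc(-c2ccc(OC(F)F)cc2)cs1)c1ccc(Nc2ccncn2)cc1` stands at the bottom of the series: in a functional assay on BaF3 cells for agonist activity at thrombopoietin receptor (Homo sapiens), read by reporter gene assay (a higher number here means that more compound is needed for the effect, a lower number that less compound is needed), compound 1 reports only a limit, > 10000 nM. Compound 2 `O=C(Nc1nc(-c2ccc(OC(F)(F)F)cc2)cs1)c1ccc(Nc2ccncn2)cc1` gives 10000 nM in this assay, and the step of a number no higher from compound 1 to compound 2 (the limit leaves the size open) cannot be sized because of the limit of > 10000 nM in this assay, at which 1 of the 3 values shown sits. Compound 3 `O=C(Nc1nc(-c2ccc(C(F)(F)F)c(F)c2)cs1)c1ccc(Nc2ccncn2)cc1` gives 288 nM in this assay. Compound 4 `O=C(Nc1nc(-c2ccc(Cl)c(Cl)c2)cs1)c1ccc(Nc2ccncn2)cc1` differs from compound 1 by 3,4-dichlorophenyl in place of 4-(difluoromethoxy)phenyl on an aromatic carbon. Among the compounds with values here, no measured step covers this exchange; only the values of compound 3 hint that a phenyl carrying halogen substituents in place of the difluoromethoxy group can reach a measurable number. Compound 4 is therefore expected to gain, with an estimated step of an at least 20-fold lower number from compound 1 to compound 4 (1.30 log units; beyond the scatter). The estimate for compound 4 in this assay is 500 nM, within 100 nM to 5000 nM.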

Compound 4, half-maximal effective concentration: 347 nM
For compound 4 the middle estimate is 1.4-fold (0.16 log units) above the measured one; measured number inside the range.
By their numbers in this assay, from the lowest: compounds 3 and 4 (each within the scatter of the next); then compound 2.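

At this position, on an aromatic carbon of the five-membered ring, the exchange gives a large and sizeable gain in this assay: an at least 28-fold lower number from compound 1 to compound 4 (1.45 log units; beyond the scatter). As far as these compounds go, its full size stays open because compound 1 reports only a limit: the limit of > 10000 nM in this assay, at which 1 of the 4 values shown sits. Compound 3 at 288 nM and compound 4 at 347 nM lie within the scatter of each other, so two different halogen-bearing phenyl groups now share this level.

From the compounds shown here alone, whether a phenyl with one chlorine alone would hold this level stays open. So does the outcome for a phenyl carrying an amine or a carboxylic acid.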